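The source may hold more compounds than are shown below. What is called first, only, known or untested is meant among the compounds shown, and "the series" means these compounds.

Of the compounds shown here, two have been measured so far. Compound 1 `Cc1cnc(N2CCC(c3coc4c(N5CCc6cc(S(C)(=O)=O)ccc65)ncnc34)CC2)nc1` in a functional assay on cells for agonist activity at Glucose-dependent insulinotropic receptor (Homo sapiens), read by a luciferase reporter, with a stated time of 4 h (on this read-out lower numbers stand for an effect already at smaller amounts and higher numbers for an effect only at larger amounts of compound), gives 252 nM. Compound 2 `CC(C)(C)OC(=O)N1CCC(c2coc3c(Nc4ccc(S(C)(=O)=O)cc4F)ncnc23)CC1`, which shares the same core but carries different groups at both ends, in this assay gives 129 nM. Compound 1 stands at one end of these two numbers and compound 2 at the other, yet the gap between them lies within the usual scatter of repeated measurements, so neither can be set apart from the other.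

The next compound to be measured is compound 3 `COc1cnc(N2CCC(c3coc4c(N5CCc6cc(S(C)(=O)=O)ccc65)ncnc34)CC2)nc1`. It differs from compound 1 in a single place: methoxy in place of methyl on an aromatic carbon. Going by the values given here, no pair of measured compounds differs in only one place, so no measured step can guide the expectation; the change is small and is expected to give a step of a 1.0-fold lower number from compound 1 to compound 3 (0.00 log units; within the scatter), that is, none beyond the scatter. Compound 3 in this assay is therefore expected to give about 250 nM, with a range from 100 nM to 630 nM.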

Compound 3, half-maximal effective concentration: 310 nM
Compound 3: middle estimate off by 1.2-fold (0.09 log units), on the low side; the measured number falls inside the stated range.
By their numbers in this assay, from the lowest: compounds 2, 1 and 3 (each within the scatter of the next, the first and the last beyond it).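

Going by these compounds alone, replacing 5-methylpyrimidin-2-yl with 5-methoxypyrimidin-2-yl gives the first comparison in which only one place differs, and in this assay it amounts to a 1.2-fold higher number from compound 1 to compound 3 (0.09 log units; within the scatter) on this read-out. Methyl and methoxy therefore cannot be told apart at this position on the ring, even though methoxy brings an extra oxygen and a hydrogen-bond acceptor that methyl lacks. Nothing measured here offers an explanation for this result.

Two groups at one position are too few to show how much this spot tolerates in general. From the compounds shown here alone, whether an amine, a carboxylic acid, a longer chain such as ethoxy, or a bare hydrogen here would shift the number beyond the scatter remains open.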